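The compounds below may be only part of what the source reports. "The series", "measured", "known", "first", "only" and "open" are said of these compounds alone.

Compound 1, `CCCCCCC/C=C\C(=O)O[C@H]1[C@H](O)[C@H](n2ccc(N)nc2=O)O[C@@H]1CO`, in a functional assay on HeLa cells (Homo sapiens) for cytotoxicity, read by cell counting, with a stated time of 48 h (a lower number here means that less compound is needed, a higher number that more compound is needed for the effect), gives 0.06 ug/mL.
Compound 2, `CCCCCCCCCC(=O)OC[C@H]1O[C@@H](n2ccc(N)nc2=O)[C@@H](O)[C@@H]1O`, in this assay gives 0.1 ug/mL.

Compound 1 has the lower of these two numbers, but compound 2 sits within the scatter of it, so no order between them can be claimed. Compound 3, `CCCCCCCCC(=O)O[C@H]1[C@H](O)[C@H](n2ccc(N)nc2=O)O[C@@H]1CO`, is not yet measured. It differs from compound 1 in one place: a group of 8 heavy atoms (8 carbon; no ring) in place of a group of 9 heavy atoms (9 carbon; no ring), on a carbonyl carbon. Octyl enters; the group that leaves has no common name. Going by the values given here, no step between measured compounds is known, so the expectation rests only on how close compound 1 and compound 2 lie. Compound 3 is expected to stay near compound 1, with an estimated step of a 1.3-fold higher number from compound 1 to compound 3 (0.12 log units; within the scatter) that does not go beyond the scatter. The estimate for compound 3 in this assay is 0.08 ug/mL, expected between 0.03 ug/mL and 0.25 ug/mL.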

Compound 3, concentration for half-maximal effect: 0.05 ug/mL
Compound 3: middle estimate off by 1.6-fold (0.20 log units), on the high side, and the stated range covers the measured number.
By their numbers in this assay, from the lowest: compounds 3, 1 and 2 (each within the scatter of the next).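

Replacing the group that carries a double bond with octyl, on a carbonyl carbon, gives a 1.2-fold lower number from compound 1 to compound 3 (0.08 log units; within the scatter) in this assay. At this position, then, a chain without that double bond and a chain with it give numbers that cannot be told apart. No measurement is at hand that would explain this closeness. As far as these compounds go, what stays open is whether a longer chain, an amine or a carboxylic acid in place of octyl would keep the number close to those of compound 1 and compound 3.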